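Swapping para-fluoro for para-hydroxy on the aryl substituent

The source may hold more compounds than are shown below. What is called first, only, known or untested is meant among the compounds shown, and "the series" means these compounds.

Of the compounds shown here, three sharing one nucleoside core have been measured in a functional assay on CCRF-CEM cells (Homo sapiens) for inhibition; a higher number here means a weaker inhibitor, a lower number a stronger inhibitor. Compound 1 `OC[C@H]1OC(n2cnc3c(-c4ccco4)ncnc32)[C@H](O)[C@@H]1O` carries a furan-2-yl group and in this assay compound 1 gives 600 nM. Compound 2 `OC[C@H]1OC(n2cnc3c(-c4ccccn4)ncnc32)[C@H](O)[C@@H]1O` carries a pyridin-2-yl group, and in this assay compound 2 gives 900 nM. Compound 3 `OC[C@H]1OC(n2cnc3c(-c4ccc(F)cc4)ncnc32)[C@H](O)[C@@H]1O` carries a 4-fluorophenyl group, and in this assay compound 3 gives 700 nM. Compound 3 thus stands second highest of the three numbers, but every step between them is within the scatter: a 1.5-fold higher number from compound 1 to compound 2 (0.18 log units; within the scatter), a 1.2-fold higher number from compound 1 to compound 3 (0.07 log units; within the scatter) and a 1.3-fold lower number from compound 2 to compound 3 (0.11 log units; within the scatter).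

Compound 4 `OC[C@H]1OC(n2cnc3c(-c4ccc(O)cc4)ncnc32)[C@H](O)[C@@H]1O` differs from compound 3 by a single change, (hydroxy in place of fluoro on an aromatic carbon). Among the compounds with values here, none of the measured steps touches this exact change; each of them replaces the whole aromatic group rather than one substituent on it, and all three stayed within the scatter. On that basis a step no larger than the scatter is expected in this assay, in no firm direction, and the step from compound 3 to compound 4 is estimated as a 1.1-fold higher number from compound 3 to compound 4 (0.06 log units; within the scatter). For compound 4 the value in this assay is therefore estimated at 800 nM, within a range from 300 nM to 2500 nM.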

Compound 4, half-maximal inhibitory concentration: 1250 nM
Beside the measured number, compound 4's estimate is 1.6-fold (0.19 log units) below it; low and high end bracket the measured number.
By their numbers in this assay, from the lowest: compounds 1, 3, 2 and 4 (each within the scatter of the next, the first and the last beyond it).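

In this assay, within the data shown here, the swap of fluoro for hydroxy on an aromatic carbon, para to a large group, is the only step here that alters one substituent rather than the whole aromatic group; it gives a 1.8-fold higher number from compound 3 to compound 4 (0.25 log units; within the scatter) and so adds a hydrogen-bond donor and acceptor at this place without separating the two compounds beyond the scatter. The step from the pyridin-2-yl group, a 1.4-fold higher number from compound 2 to compound 4 (0.14 log units; within the scatter), also stays within the scatter, whereas the step from the furan-2-yl group, a 2.1-fold higher number from compound 1 to compound 4 (0.32 log units; beyond the scatter), is the only one among these four compounds to pass beyond it, and that only modestly, so the four groups at this position span a modest range of numbers. No supporting measurement bears on what lies behind these steps.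

Going by these compounds, whether the hydroxy hydrogen itself matters stays open, since a methoxy group at this place would be needed to separate it from the oxygen, and whether an amine or a carboxylic acid here would widen the range is equally unknown. The compounds shown also leave open whether steps of this size would hold in any setting other than this assay.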